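This account rests on a few compounds, and the source may have more. Where it says the series, first, only, none or still open, it means among the compounds named here.

In an ADME assay on PBMC cells (Homo sapiens) for inhibition, read by MTT assay (on this read-out lower numbers stand for stronger inhibition and higher numbers for weaker inhibition), compound 1 `CC1=CCC[C@H]2[C@](C)(CC3=CC(=O)C=CC3=O)[C@@H](C)CC[C@]12C` gives 4500 nM. Within the data shown here, that is the only number available, so compound 1 cannot yet be ranked against any relative. The one other entry, compound 2 `CCCSC1=CC(=O)C(C[C@]2(C)[C@@H](C)CC[C@]3(C)C(C)=CCC[C@@H]23)=CC1=O`, offers no comparison, since for compound 2 the record reads "not determined" (no result reported).

The next compound to be measured is compound 3 `CNC1=CC(=O)C=C(C[C@]2(C)[C@@H](C)CC[C@]3(C)C(C)=CCC[C@@H]23)C1=O`, which keeps the core of compound 1 but carries methylamino in place of hydrogen on a double-bonded ring carbon. Among the measured compounds shown here, no pair of measured compounds shows what a change of this kind does in this assay, so any forecast has to stay cautious and wide. A small weakening is expected, probably not far beyond the usual scatter of repeated measurements. The estimated step of a 1.6-fold higher number from compound 1 to compound 3 (0.19 log units; within the scatter) reflects that modest expectation. Compound 3 is expected to read about 7000 nM, with an estimated range of 2500 nM to 20000 nM.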

Compound 3, half-maximal inhibitory concentration: 4200 nM
For compound 3 the middle estimate is 1.7-fold (0.22 log units) above the measured one, and the stated range covers the measured number.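

In this assay, placing methylamino in place of hydrogen on a double-bonded ring carbon gives a 1.1-fold lower number from compound 1 to compound 3 (0.03 log units; within the scatter) and so leaves the two compounds indistinguishable on this read-out. Among these compounds, this is the first measured pair to test a change at this position, and it shows that the ring carbon can carry methylamino without the reading moving beyond the usual scatter of repeated measurements. No measurement is available to explain this result.

This single pair cannot show whether a longer chain such as propylamino, or a carboxylic acid, on the same ring carbon would also leave the reading within the scatter. Compound 2 offers no help with this question, as no result is reported for it.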